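A second fluorine on the amide phenyl group

The source may hold more compounds than are shown below. What is called first, only, known or untested is meant among the compounds shown, and "the series" means these compounds.

Of the compounds shown here, three sharing one core have been measured in a physicochemical assay for lipophilicity, at pH 7.4; on this read-out higher numbers stand for higher lipophilicity and lower numbers for lower lipophilicity. Compound 1 `Cc1cc(C(N)=O)nn1Cc1cc(Cl)ccc1OCc1ccccc1` gives 3.7. For compound 2 `CNC(=O)c1cc(C)n(Cc2cc(Cl)ccc2OCc2ccccc2)n1` the read-out is a limit of the assay, > 3.7 (the limit of > 3.7 in this assay, at which 1 of the 3 values shown sits). Compound 3 `Cc1cc(C(=O)Nc2cccc(F)c2)nn1Cc1cc(Cl)ccc1OCc1ccccc1` gives 2.8, the lowest of the two numbers shown. Its nearest neighbour on the numbers is compound 1, and the step of a number 0.90 log units lower from compound 1 to compound 3 (beyond the scatter) lies beyond the scatter. The step of a number at least 0.90 log units lower from compound 2 to compound 3 (beyond the scatter) is also beyond the scatter, whereas a number no lower from compound 1 to compound 2 (the limit leaves the size open) is open in size.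

Compound 4 `Cc1cc(C(=O)Nc2c(F)cccc2F)nn1Cc1cc(Cl)ccc1OCc1ccccc1` differs from compound 3 in one place: 2,6-difluorophenyl in place of 3-fluorophenyl on an amide-type nitrogen. Both measured steps ending at compound 3 exchange hydrogen or methyl for a fluorinated phenyl ring on the amide nitrogen; neither alters the number of fluorines on a ring already present, so none of them bears directly on the present change, which leaves the ring count, the donor count and the acceptor count unchanged. From compound 3 to compound 4 the expected movement is a number 0.10 log units higher from compound 3 to compound 4 (within the scatter), a step not beyond the scatter. For compound 4 the estimate in this assay is 2.9, with a range from 2.5 to 3.3.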

Compound 4, distribution coefficient: 3.7
The estimate for compound 4 lay 0.80 log units below the measured number; the measured number lies above the stated range.
By their numbers in this assay, from the lowest: compound 3; then compounds 1 and 4 (each within the scatter of the next).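

The change from 3-fluorophenyl to 2,6-difluorophenyl on the amide-type nitrogen is the only step shown that alters the phenyl group itself rather than replacing hydrogen or methyl, and in this assay it is a modest step: a number 0.90 log units higher from compound 3 to compound 4 (beyond the scatter). Going by these compounds alone, the drop seen with compound 3 therefore does not extend to every fluorinated phenyl group on this nitrogen, since the step from the unsubstituted amide to the difluorinated one reads no change at the digits printed from compound 1 to compound 4 (within the scatter), leaving compound 3 as the only compound here that stands apart from compound 1. The remaining step, a number no higher from compound 2 to compound 4 (the limit leaves the size open), cannot be read, because the entry for compound 2 is a limit and not a number: the limit of > 3.7 in this assay, at which 1 of the 4 values shown sits.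

The 3-fluorophenyl and 2,6-difluorophenyl groups differ both in the count of fluorines and in where they sit, and the compounds shown do not separate these two differences. They also leave open how an unsubstituted phenyl group, a chlorophenyl group or a pyridine ring on the same nitrogen would read in this assay.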